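The source may hold more compounds than are shown below. What is called first, only, known or untested is meant among the compounds shown, and "the series" means these compounds.

The three measured compounds share one core, an amide bridging two aromatic rings, and differ only in single substituents. Compound 1 `O=C(Nc1cc(-c2ccccc2)[nH]n1)c1ccc(Br)nc1` is the parent of the set; in a functional assay on A-375 cells (Homo sapiens) for antiproliferative activity, read by MTT assay, with a stated time of 48 h (on this read-out lower numbers stand for stronger inhibition and higher numbers for weaker inhibition), compound 1 gives 8870 nM. Compound 2 `O=C(Nc1cc(-c2ccccc2)[nH]n1)c1ccc(Cl)nc1` differs from compound 1 by chloro in place of bromo on an aromatic carbon, and in this assay compound 2 gives 7850 nM; the step is a 1.1-fold lower number from compound 1 to compound 2 (0.05 log units; within the scatter). Compound 3 `Cc1ccc(-c2cc(NC(=O)c3ccc(Br)nc3)n[nH]2)cc1` differs from compound 1 on the other side of the core by methyl in place of hydrogen on an aromatic carbon; in this assay compound 3 gives 7670 nM, and the step is a 1.2-fold lower number from compound 1 to compound 3 (0.06 log units; within the scatter). Among the measured compounds shown here, all three numbers sit within the scatter of one another, so no compound of the three can be set apart from the others.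

Compound 4 `Cc1ccc(-c2cc(NC(=O)c3ccc(Cl)nc3)n[nH]2)cc1` has not yet been measured. It differs from compound 3 by chloro in place of bromo on an aromatic carbon, which is the same change that leads from compound 1 to compound 2, made on the core of compound 3 rather than on the core of compound 1. The place of the change is described in the same words in both cases. Because the earlier exchange gave a 1.1-fold lower number from compound 1 to compound 2 (0.05 log units; within the scatter), a step that stayed within the scatter, the estimated step of a 1.1-fold lower number from compound 3 to compound 4 (0.04 log units; within the scatter) is expected to be of the same small size. In this assay compound 4 is therefore expected to give about 7000 nM, with the measured number most likely falling between 4000 nM and 12500 nM.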

Compound 4, half-maximal inhibitory concentration: 6880 nM
The estimate for compound 4 lay 1.0-fold (0.01 log units) above the measured number, within the range that was stated.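

In this assay, chloro in place of bromo on the core of compound 3 gives a 1.1-fold lower number from compound 3 to compound 4 (0.05 log units; within the scatter), and set beside the earlier exchange, this step shows no difference between the two cores: the same change on two cores in this assay, a 1.1-fold lower number (0.05 log units; within the scatter) from compound 1 to compound 2 and a 1.1-fold lower number (0.05 log units; within the scatter) from compound 3 to compound 4, 1.0-fold (0.01 log units) apart, within the scatter of two such steps. Methyl in place of hydrogen on an aromatic carbon, made on the core of compound 2, gives a 1.1-fold lower number from compound 2 to compound 4 (0.06 log units; within the scatter), and this second change also reads alike on both cores: the same change on two cores in this assay, a 1.2-fold lower number (0.06 log units; within the scatter) from compound 1 to compound 3 and a 1.1-fold lower number (0.06 log units; within the scatter) from compound 2 to compound 4, 1.0-fold (0.01 log units) apart, within the scatter of two such steps. Among the compounds shown here, since every one of these steps lies within the scatter, the agreement shows only that neither change has a readable effect on either core; it does not show that a real effect would carry from one core to another, nor that these results would hold on any core outside these four compounds.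

The compounds shown leave open whether any other group in place of the bromo or chloro, such as an amine or a carboxylic acid, would move the number beyond the scatter. They also leave open whether a longer chain or a methoxy group in place of the methyl would do so, and whether such a step would then carry from one core to another.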